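The compounds below may be only part of what the source reports. "The series", "measured", "known", "first", "only" and "open" are said of these compounds alone.

The measured compounds:
Compound 1 `O=C(CSc1nnnn1-c1cccc2ccccc12)N/N=C/c1ccco1` gives only a limit of the assay, > 330000 nM, in an ADME assay on MT4 cells (Homo sapiens) for cytotoxicity, read by MTT assay; on this read-out higher numbers stand for lower toxicity in this test and lower numbers for higher toxicity in this test.
Compound 2 `O=C(CSc1nnnn1-c1cccc2ccccc12)N/N=C/c1ccc([N+](=O)[O-])cc1` gives only a limit of the assay, >= 260000 nM, in this assay.

Within the data shown here, compound 1 therefore stands at a limit in this assay, and so does the only other compound measured there. Among the measured compounds shown here, the single measured step, a step that the two limits leave unreadable from compound 1 to compound 2, is one that the two limits leave unreadable; it is the only step that bears on the change now considered, and it gives no size and no direction.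

Compound 3 `O=C(CSc1nnnn1-c1cccc2ccccc12)N/N=C/c1cccc(O)c1` differs from compound 1 by 3-hydroxyphenyl in place of furan-2-yl on a carbon with a double bond to nitrogen. With both known values sitting at limits, there is no basis in the data for expecting any readable step; compound 3 is expected to show an at least 1.1-fold lower number from compound 1 to compound 3 (0.04 log units; that floor lies within the scatter) in this assay, that is, no change beyond the scatter. The estimate for compound 3 in this assay is 300000 nM, with a range from 100000 nM to 1000000 nM, most likely reported again only as a limit.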

Compound 3, half-maximal cytotoxic concentration: 169000 nM
Compound 3: middle estimate off by 1.8-fold (0.25 log units), on the high side, and the stated range covers the measured number.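

Among these compounds, at this place, on a carbon with a double bond to nitrogen, 3-hydroxyphenyl gives the first value in this assay that is a number and not a limit of the assay, so the change can now be read at least in part. Putting 3-hydroxyphenyl in place of furan-2-yl gives an at least 1.9-fold lower number from compound 1 to compound 3 (0.29 log units; that floor lies within the scatter), and putting it in place of 4-nitrophenyl gives an at least 1.5-fold lower number from compound 2 to compound 3 (0.18 log units; that floor lies within the scatter). Both are only floors lying within the scatter, so neither fixes the true size of the step.

The compounds shown leave open whether the hydroxy group or the six-membered ring lies behind this number, which an unsubstituted phenyl would help to tell. Also open, going by these compounds, is how an amine or a carboxylic acid on the phenyl ring would read in this assay.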